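Moving the ring nitrogen within the five-membered heteroaryl

The source may report more compounds than this note shows. Statements on the series, on what has been measured and on what is new or still open speak of the compounds shown alone.

Three compounds share a phenoxy-methyl-imidazoline core and differ only in the aromatic group attached to the benzene ring. Compound 1 `c1cnc(-c2ccccc2OCC2=NCCN2)nc1`, carrying pyrimidin-2-yl, gives 1260 nM in a functional assay for activation of Alpha-1A adrenergic receptor (Homo sapiens), read by calcium flux; on this read-out lower numbers stand for an effect already at smaller amounts and higher numbers for an effect only at larger amounts of compound. Compound 2 `c1c[nH]c(-c2ccccc2OCC2=NCCN2)c1` gives 1.26 nM, and compound 3 `c1ccc(-c2ccns2)c(OCC2=NCCN2)c1` gives 5.01 nM. Compound 3 thus sits second highest of the three numbers: its value is a 4.0-fold higher number from compound 2 to compound 3 (0.60 log units; beyond the scatter), while a 250-fold lower number from compound 1 to compound 3 (2.40 log units; beyond the scatter).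

Compound 4 `c1ccc(-c2nccs2)c(OCC2=NCCN2)c1` is the next structure. The change from compound 3 is 1,3-thiazol-2-yl in place of 1,2-thiazol-5-yl on an aromatic carbon, so the same atoms are joined differently. Within the data shown here, the steps that bear on it are the swaps among five-membered and six-membered heteroaryls: a 1000-fold lower number from compound 1 to compound 2 (3.00 log units; beyond the scatter), a 250-fold lower number from compound 1 to compound 3 (2.40 log units; beyond the scatter) and a 4.0-fold higher number from compound 2 to compound 3 (0.60 log units; beyond the scatter). Both five-membered rings gave low numbers, whereas the six-membered pyrimidin-2-yl gave a high one. Since compound 4 keeps a five-membered ring with one nitrogen and one sulfur, only a modest shift is expected, estimated as a 4.0-fold higher number from compound 3 to compound 4 (0.60 log units; beyond the scatter). Compound 4 is therefore expected to give about 20 nM, within 3 nM to 150 nM.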

Compound 4, half-maximal effective concentration: 2.51 nM
The estimate for compound 4 lay 8.0-fold (0.90 log units) above the measured number, and the stated range ends above it.
By their numbers in this assay, from the lowest: compounds 2, 4 and 3 (each within the scatter of the next, the first and the last beyond it); then compound 1.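

In this assay, the new result gives a 2.0-fold lower number from compound 3 to compound 4 (0.30 log units; within the scatter) and a 2.0-fold higher number from compound 2 to compound 4 (0.30 log units; within the scatter), both within the scatter, so at this place, on an aromatic carbon ortho to a group of 7 heavy atoms, 1,3-thiazol-2-yl cannot be told apart from either 1,2-thiazol-5-yl or 1H-pyrrol-2-yl. Against pyrimidin-2-yl the gap stays large, at a 500-fold lower number from compound 1 to compound 4 (2.70 log units; beyond the scatter), so three five-membered heteroaryls now stand clearly apart from this one six-membered ring. No measured evidence here accounts for that gap.

The compounds shown leave open whether the high number of compound 1 belongs to six-membered rings generally or to pyrimidin-2-yl alone, a question on which phenyl or pyridin-2-yl at this place would bear. Also open, from the compounds shown here alone, is how a ring with oxygen, such as furan-2-yl, would compare.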